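From benzyl to 2-(2-hydroxyethoxy)ethyl on compound 2

This account rests on a few compounds, and the source may have more. Where it says the series, first, only, none or still open, it means among the compounds named here.

In a functional assay on HT-29 cells (Homo sapiens) for cytotoxicity (a lower number here means a stronger inhibitor, a higher number a weaker inhibitor), compound 1 `Nc1[nH]nc2nncc(-c3ccccc3)c12` gives > 100000 nM as a limit of the assay and not a number. Compound 2 `Nc1nn(Cc2ccccc2)c2nnc(-c3ccccc3)c(-c3ccccc3)c12` gives > 100000 nM as a limit too. Compound 3 `Nc1[nH]nc2nnc(-c3ccc(-c4ccccc4)cc3)c(-c3ccc(-c4ccccc4)cc3)c12` likewise gives > 100000 nM as a limit. Compound 2 therefore has no number of its own, and the two further readings are limits as well, so the picture so far is the limit of > 100000 nM in this assay, at which 3 of the 3 values shown sit, with no exception.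

Compound 4 `Nc1nn(CCOCCO)c2nnc(-c3ccccc3)c(-c3ccccc3)c12` changes compound 2 on a saturated chain carbon bound to an aromatic nitrogen, where benzyl gives way to 2-(2-hydroxyethoxy)ethyl (2-hydroxyethoxy)methyl in place of phenyl on a saturated chain carbon bound to an aromatic nitrogen and the rest of the molecule stays the same. Going by the values given here, no measured step exists to size such a change in this assay and the only guide is compound 2 with its limit of > 100000 nM as the reference. The step of a number no higher from compound 2 to compound 4 (the limit leaves the size open) is therefore expected to stay within the scatter, with no direction favoured. Compound 4 is estimated at 100000 nM with an expected range from 40000 nM to 250000 nM and will most likely be reported as a limit again.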

Compound 4, half-maximal inhibitory concentration: > 100000 nM
Compound 4 ended at the assay's limit (the forecaster's own chance of this, stated with the estimate: 80%); the middle value lies on the limit itself.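

Compound 2 and compound 4 both end at a limit of the assay and not at a number, so the step between them cannot be read. The compounds shown leave open whether any change to the shared core would give a measurable number in this assay.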